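A few compounds are considered here, and "the series" means these few. Any claim that something is new, unique, unknown or untested is made for them only; others in the source may bear on it.

Three compounds that share one core have been examined in an ADME assay on NCM460 cells (Homo sapiens) for cytotoxicity, read by MTT assay, with a stated time of 72 h; on this read-out lower numbers stand for stronger inhibition and higher numbers for weaker inhibition. Among the measured compounds shown here, compound 1 `CCc1cccc(NC(=O)c2cccc(/C=C3\CC(=O)N(Cc4ccccc4)C3=O)c2)c1` is the first of them; in this assay compound 1 gives > 100000 nM, which is a limit of the assay rather than a number. Compound 2 `CCc1cccc(NC(=O)c2cccc(/C=C3\CC(=O)N(c4ccccc4)C3=O)c2)c1` differs from it by phenyl in place of benzyl on an amide-type nitrogen in a ring, and in this assay compound 2 gives > 100000 nM, again a limit. Compound 3 `COc1ccc(OC)c(NC(=O)c2cccc(/C=C3\CC(=O)N(c4ccccc4)C3=O)c2)c1` carries 2,5-dimethoxyphenyl in place of 3-ethylphenyl on an amide-type nitrogen, and in this assay compound 3 gives > 100000 nM, once more a limit. Compound 3 thus stands where every value shown stands, namely at the limit of > 100000 nM in this assay, at which 3 of the 3 values shown sit. The step that the two limits leave unreadable from compound 1 to compound 2 and the step that the two limits leave unreadable from compound 2 to compound 3 are for that reason both of unreadable size.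

Compound 4 `CSc1cccc(NC(=O)c2cccc(/C=C3\CC(=O)N(c4ccccc4)C3=O)c2)c1` has not yet been measured. Its change from compound 3 is 3-(methylsulfanyl)phenyl in place of 2,5-dimethoxyphenyl on an amide-type nitrogen. For the measured compounds named here, both measured steps bear on this change in that each swaps the group on a nitrogen, yet neither could be read, so no size or direction can be drawn from them; the only guide is the limit of > 100000 nM in this assay, at which 3 of the 3 values shown sit. For compound 4 the expectation is that the step that the limit leaves unreadable from compound 3 to compound 4 stays within the scatter. Compound 4 is therefore estimated at 150000 nM, ranging from 60000 nM to 400000 nM, and most likely reported again only as a limit.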

Compound 4, half-maximal inhibitory concentration: > 100000 nM
Compound 4: a limit, no number (the forecaster's own chance of this, stated with the estimate: 85%); the middle value does not contradict the limit.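

Compound 4 gives > 100000 nM in this assay, which is a limit and not a number. Compound 2 and compound 3 also stand at a limit, so the steps to compound 4 from each of them cannot be read: the limit of > 100000 nM in this assay, at which 4 of the 4 values shown sit.

The compounds shown leave open how far apart these four compounds truly lie, and whether any change to the shared core would yield a measurable number in this assay.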